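The source may hold more compounds than are shown below. What is called first, only, known or untested is meant among the compounds shown, and "the series" means these compounds.

Measured compounds in an ADME assay on HCT-116 cells (Homo sapiens) for cytotoxicity, read by CellTiter-Glo, with a stated time of 72 h; on this read-out higher numbers stand for weaker inhibition and lower numbers for stronger inhibition:
compound 1 `CC1CCN(C2CCN(S(=O)(=O)c3ccc(C(C)C)cc3)CC2)CC1`: > 5000 nM, a limit of this assay
compound 2 `CC1CCN(C2CCN(S(=O)(=O)c3cccc(C(F)(F)F)c3)CC2)CC1`: > 5000 nM, a limit of this assay
compound 3 `CC1CCN(C2CCN(S(=O)(=O)c3ccc(Cl)cc3Cl)CC2)CC1`: > 5000 nM, a limit of this assay

All three measured compounds share one core and differ only in the substituent on the aryl sulfonyl group. None of them gives a number in this assay; each sits at a limit, and compound 1 is no exception, so its position is known only as a limit (the limit of > 5000 nM in this assay, at which 3 of the 3 values shown sit). Nothing in these three values separates one from another.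

Compound 4 `CC1CCN(C2CCN(S(=O)(=O)c3ccc(-c4ccccc4F)cc3)CC2)CC1` has not yet been measured. Compared with compound 1 it carries the change (2-fluorophenyl in place of isopropyl on an aromatic carbon). Among the measured compounds shown here, no step between measured compounds exists to lean on, so the size and direction of the step from compound 1 to compound 4 in this assay cannot be drawn from measured data. With three compounds at the limit, the expectation is that the step from compound 1 to compound 4 is a step that the limit leaves unreadable from compound 1 to compound 4, that is, no change beyond the scatter. Compound 4 is therefore expected to give about 8000 nM, within a range of 2000 nM to 30000 nM, most likely again reported only as a limit.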

Compound 4, half-maximal inhibitory concentration: > 5000 nM
Compound 4: no number, only a limit; the forecaster's own chance of this, stated with the estimate: 65%; the middle value does not contradict the limit.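

Compound 4, like compound 1, gives only a limit in this assay, so the step from compound 1 to compound 4 cannot be read: the limit of > 5000 nM in this assay, at which 4 of the 4 values shown sit.

The compounds shown leave open whether any of them differs from another in this assay, and at what concentration any of them would reach half-maximal inhibition.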